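The source may report more compounds than this note shows. Statements on the series, on what has been measured and on what is new or still open speak of the compounds shown alone.

Measured so far:
compound 1, `Cc1cc(O)c(C2=NN(c3ccc(S(N)(=O)=O)cc3)C(c3ccccc3Cl)C2)cc1Cl`: 4040 nM
compound 2, `Cc1cc(O)c(C2=NN(c3ccc(S(N)(=O)=O)cc3)C(/C=C/c3ccccc3)C2)cc1Cl`: 17700 nM

Both numbers come from a functional assay on MOLT-4 cells (Homo sapiens) for antiproliferative activity, with a stated time of 48 h; a lower number here means a stronger inhibitor of growth, a higher number a weaker inhibitor of growth. Among the compounds with values here, compound 2 stands at the higher of the two numbers; the only measured step is a 4.4-fold higher number from compound 1 to compound 2 (0.64 log units; beyond the scatter), a modest change. Compound 3, `COc1ccc(C2CC(c3cc(Cl)c(C)cc3O)=NN2c2ccc(S(N)(=O)=O)cc2)cc1OC`, differs from compound 2 in one place: 3,4-dimethoxyphenyl in place of 2-phenylethenyl on a saturated ring carbon. Within the data shown here, the aromatic ring is thus again attached directly to the saturated ring carbon, as it is in compound 1, whereas the two methoxy groups have no counterpart among the measured compounds, so no step speaks to them. Among the measured compounds shown here, the one measured step runs the other way, from a directly attached aromatic ring to the 2-phenylethenyl group, and raised the number. For compound 3 the number is therefore expected to come back down, with a 3.5-fold lower number from compound 2 to compound 3 (0.55 log units; beyond the scatter), toward where compound 1 sits, with the uncertainty widened for the unprecedented methoxy groups. The estimate for compound 3 is 5000 nM, expected to lie within 1800 nM to 15000 nM.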

Compound 3, concentration for 50% growth inhibition: 5290 nM
For compound 3 the middle estimate is 1.1-fold (0.02 log units) below the measured one, within the range that was stated.
By their numbers in this assay, from the lowest: compounds 1 and 3 (each within the scatter of the next); then compound 2.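

On the saturated ring carbon, in this assay, replacing the 2-phenylethenyl group with 3,4-dimethoxyphenyl gives a 3.3-fold lower number from compound 2 to compound 3 (0.52 log units; beyond the scatter), so compound 1 and compound 3, the two compounds with an aromatic ring attached directly at this carbon, both stand apart from compound 2. Within the data shown here, the comparison of the two aromatic groups gives a 1.3-fold higher number from compound 1 to compound 3 (0.12 log units; within the scatter), so in this assay 3,4-dimethoxyphenyl cannot be told apart from 2-chlorophenyl, even though the two groups share no substituent, and the series so far tolerates this difference in ring substitution. No supporting measurement bears on the reason for either step.

The compounds shown leave open whether a ring attached directly at this carbon must be aromatic, which a cyclohexyl group would test, and whether a phenyl group with no substituents or with a single methoxy group would read the same as these two aromatic groups. They also leave open how a charged or strongly polar group at this carbon, such as an aminomethyl group or a carboxylic acid, would read in this assay.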